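A few compounds are considered here, and "the series" means these few. Any claim that something is new, unique, unknown or untested is made for them only; others in the source may bear on it.

Measured so far in an ADME assay on HEK293 cells (Homo sapiens) for cytotoxicity, read by MTT assay, with a stated time of 24 h; a higher number here means a weaker inhibitor, a lower number a stronger inhibitor

Compound 1 `O=C1/C(=C/c2ccccc2F)CN(Cc2cn(Cc3cccc(Cl)c3)nn2)C/C1=C\c1ccccc1F` gives 33100 nM
Compound 2 `O=C1/C(=C/c2ccccc2F)CN(Cc2cn(Cc3ccccc3Cl)nn2)C/C1=C\c1ccccc1F` gives 33200 nM

Compound 2 at 33200 nM lies within the scatter of compound 1, so the two cannot be ranked. Compound 3 `O=C1/C(=C/c2ccccc2F)CN(Cc2cn(Cc3ccc(F)cc3)nn2)C/C1=C\c1ccccc1F` has not been measured yet. It differs from compound 2 by 4-fluorophenyl in place of 2-chlorophenyl on a saturated chain carbon bound to an aromatic nitrogen with 4-fluorophenyl in place of 2-chlorophenyl on a saturated chain carbon bound to an aromatic nitrogen. Going by the values given here, the only measured step at this place is a 1.0-fold higher number from compound 1 to compound 2 (0.00 log units; within the scatter) and it bears on the change only indirectly, as it swaps 3-chlorophenyl for 2-chlorophenyl. Among the compounds with values here, no measured compound carries 4-fluorophenyl, which leaves that single step as the whole basis for the expectation. In this assay the expected change is a 1.0-fold lower number from compound 2 to compound 3 (0.00 log units; within the scatter) and so none beyond the scatter, in either direction. For compound 3 the estimated value is 33000 nM with an expected range from 16000 nM to 65000 nM for a measurement.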

Compound 3, half-maximal inhibitory concentration: 46000 nM
Beside the measured number, compound 3's estimate is 1.4-fold (0.14 log units) below it; the measured number falls inside the stated range.
By their numbers in this assay, from the lowest: compounds 1, 2 and 3 (each within the scatter of the next).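

In this assay the swap of 2-chlorophenyl for 4-fluorophenyl on a saturated chain carbon bound to an aromatic nitrogen gives a 1.4-fold higher number from compound 2 to compound 3 (0.14 log units; within the scatter) and the swap of 3-chlorophenyl for 4-fluorophenyl gives a 1.4-fold higher number from compound 1 to compound 3 (0.14 log units; within the scatter). The earlier pair differed only in where the chlorine sat, whereas these steps also change the halogen, and at this position that change still leaves the number within the scatter of both chlorinated compounds. Nothing available explains this reading. The compounds shown carry only a halogen on this phenyl group, so it remains open whether an amine or a carboxylic acid there would also stay within the scatter. From the compounds shown here alone, what a change elsewhere on the shared core would do also remains open.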